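Azole exchange on compound 2, expected outcome

The source may hold more compounds than are shown below. What is called first, only, known or untested is meant among the compounds shown, and "the series" means these compounds.

Three compounds of the series have numbers in a functional assay for antagonist activity at Neuropeptides B/W receptor type 1 (Homo sapiens), read by cAMP accumulation (a higher number here means a weaker inhibitor, a lower number a stronger inhibitor), so far. Compound 1 `NS(=O)(=O)c1ccc(-c2nc3cc([N+](=O)[O-])ccc3[nH]2)cc1` reaches only the limit of the assay, and in this assay compound 1 gives > 31600 nM; this is a limit, not a number. Compound 3 `O=[N+]([O-])c1ccc2[nH]c(-c3cccc(Cl)c3)nc2c1` gives 9980 nM in this assay. Compound 2 `FC(F)(F)c1ccc2[nH]c(-c3ccc(-c4nnc[nH]4)cc3)nc2c1` gives 3080 nM in this assay, the lowest of the two numbers; the nearest, compound 3, sits higher by a gap beyond the scatter. Compound 1 adds only a limit (the limit of > 31600 nM in this assay, at which 1 of the 3 values shown sits).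

Compound 4 `FC(F)(F)c1ccc2[nH]c(-c3ccc(-c4c[nH]nc4C(F)(F)F)cc3)nc2c1` differs from compound 2 in one place: 3-(trifluoromethyl)-1H-pyrazol-4-yl in place of 4H-1,2,4-triazol-3-yl on an aromatic carbon. For the measured compounds named here, no measured pair shows such a change, so its size cannot be read from the data. The shared core and the remaining substituent are kept, and a hydrogen-bond donor is retained on the new ring, so the expected step from compound 2 to compound 4 is small, likely within the scatter, with no direction favoured: a 1.0-fold lower number from compound 2 to compound 4 (0.01 log units; within the scatter). Compound 4 is therefore estimated at 3000 nM in this assay, within 900 nM to 10000 nM.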

Compound 4, half-maximal inhibitory concentration: 1200 nM
For compound 4 the middle estimate is 2.5-fold (0.40 log units) above the measured one; measured number inside the range.
By their numbers in this assay, from the lowest: compound 4; then compound 2; then compound 3. At a limit, above all of these: compound 1.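

In this assay, for the compounds shown here, a 2.6-fold lower number from compound 2 to compound 4 (0.41 log units; beyond the scatter), the first one-place comparison, shows that this position, on an aromatic carbon para to a large group, responds to an exchange of one azole for another. The entering 3-(trifluoromethyl)-1H-pyrazol-4-yl has 9 heavy atoms against 5 in 4H-1,2,4-triazol-3-yl and is tolerated here, with the lower number kept despite 1 hydrogen-bond acceptor in place of 2. No measurement among those shown bears on the reason for this step.

The trifluoromethyl group and the change of ring enter together, leaving the share of each in the step open. Also open, on these data alone, is whether a methyl group in place of the trifluoromethyl, or a carboxylic acid or an amine at this position, would match compound 4 at 1200 nM.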